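This account rests on a few compounds, and the source may have more. Where it says the series, first, only, none or still open, it means among the compounds named here.

Three compounds share one core and differ only in the group carried on the nitrogen attached to the aromatic ring. Compound 1 `Cc1ccc(S(=O)(=O)c2cc3cnc(Nc4ccc5[nH]ccc5c4)nc3n(C)c2=O)cc1` gives 750 nM in a functional assay on K562 cells (Homo sapiens) for inhibition, read by trypan blue exclusion, with a stated time of 72 h (on this read-out higher numbers stand for weaker inhibition and lower numbers for stronger inhibition), the lowest of the three numbers. Compound 2 `Cc1ccc(S(=O)(=O)c2cc3cnc(Nc4cccc5cccnc45)nc3n(C)c2=O)cc1` gives 10000 nM, and compound 3 `Cc1ccc(S(=O)(=O)c2cc3cnc(Nc4cnc5c(c4)CC(=O)N5)nc3n(C)c2=O)cc1` gives 15000 nM. The step of a 13-fold higher number from compound 1 to compound 2 (1.12 log units; beyond the scatter) and the step of a 20-fold higher number from compound 1 to compound 3 (1.30 log units; beyond the scatter) are both large, while the step of a 1.5-fold higher number from compound 2 to compound 3 (0.18 log units; within the scatter) is within the scatter; so the group on that nitrogen matters a great deal, and the 1H-indol-5-yl of compound 1 is the one that goes with the lowest number.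

Compound 4 `Cn1c(=O)c(S(=O)(=O)c2ccc(Br)cc2)cc2cnc(Nc3ccc4[nH]ccc4c3)nc21` keeps the 1H-indol-5-yl of compound 1 and alters a different part: bromo in place of methyl on an aromatic carbon, so that a (4-methylphenyl)sulfonyl becomes a (4-bromophenyl)sulfonyl. Among the measured compounds shown here, none of the measured steps touches this part of the molecule, so there is no direct precedent for the change; the only guidance is that the variable group on the nitrogen, which drove the measured steps, is left as in compound 1. On that basis compound 4 is expected to stay close to compound 1, with a 1.1-fold higher number from compound 1 to compound 4 (0.03 log units; within the scatter) as the estimated step, within the scatter. The estimate for compound 4 is 800 nM, with a range from 300 nM to 2500 nM.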

Compound 4, half-maximal inhibitory concentration: 5000 nM
Compound 4: middle estimate off by 6.3-fold (0.80 log units), on the low side; the whole stated range lies below it.
By their numbers in this assay, from the lowest: compound 1; then compounds 4, 2 and 3 (each within the scatter of the next, the first and the last beyond it).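

Among the compounds shown here, the (4-methylphenyl)sulfonyl part, which no earlier step touched, is not a silent part of the molecule: with the 1H-indol-5-yl kept in place, going to (4-bromophenyl)sulfonyl gives a 6.7-fold higher number from compound 1 to compound 4 (0.82 log units; beyond the scatter) in this assay. The group on the nitrogen is therefore not the only place that moves this number, and replacing one heavy atom with another on an aromatic carbon is enough to weaken inhibition beyond the scatter, even though the count of rings, hydrogen-bond donors and hydrogen-bond acceptors stays the same and neither group carries a net charge. Nothing available explains why bromo goes with a higher number than methyl here.

As far as these compounds go, only methyl and bromo are seen at this place, so it remains open how a chloro, a methoxy or an amine there would read, and one pair cannot show whether methyl helps, bromo hurts, or both. Also open, from the compounds shown here alone, is whether bromo in place of methyl would give a similar step with the quinolin-8-yl of compound 2 or the other nitrogen group of compound 3.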